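The source may hold more compounds than are shown below. What is called first, only, known or untested is meant among the compounds shown, and "the series" means these compounds.

Working notes on the series in an ADME assay on BJ cells (Homo sapiens) for cytotoxicity, with a stated time of 72 h; on this read-out higher numbers stand for an effect only at larger amounts of compound and lower numbers for an effect already at smaller amounts: every reading so far is a limit, not a number.

Compound 1 (`C=C[C@@](C)(/C=C/c1ccc(OS(=O)(=O)C(F)(F)F)cc1)CCC=C(C)C`) reads > 36600 nM, a limit. Compound 2 (`C=C[C@@](C)(/C=C/c1ccc(O)c(/C=C/C#N)c1)CCC=C(C)C`) reads > 36600 nM, also a limit. Compound 3 (`COc1ccc(/C=C/[C@@](C)(/C=C/c2ccc(O)c(/C=C/C#N)c2)CCC=C(C)C)cc1`) reads > 23700 nM, again a limit, so it has no numeric place in the series.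

Compound 4 (`COc1ccc(/C=C/[C@@](C)(/C=C/c2ccc(O)c(/C=C/C(=O)c3ccccc3)c2)CCC=C(C)C)cc1`) is the next entry, with the change (benzoyl in place of cyano on a double-bonded chain carbon bound to a double-bonded chain carbon). This puts benzoyl in place of cyano on a double-bonded chain carbon bound to a double-bonded chain carbon, which also reads as 2-cyanoethenyl to 2-benzoylethenyl.

Among the measured compounds shown here, the only measured step is a step that the two limits leave unreadable from compound 2 to compound 3. It has 2-(4-methoxyphenyl)ethenyl in place of vinyl, a different change at a different place, so it supplies no size to carry over.

With only limits behind it, the expected change in this assay is small and, if it shows at all, toward lower numbers. The expected step is an at least 1.1-fold lower number from compound 3 to compound 4 (0.07 log units; that floor lies within the scatter), and another limit remains a likely report. For compound 4 the estimate is 20000 nM, with an expected range of 7000 nM to 40000 nM.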

Compound 4, half-maximal effective concentration: > 36600 nM
Compound 4 was reported as a limit (the forecaster's own chance of this, stated with the estimate: 60%); middle value at least 1.8-fold (0.26 log units) from the limit.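

Compound 3 and compound 4 both stand as limits, not numbers, so the change from cyano to benzoyl gives no readable step. The compounds shown leave open at what concentration any of them would reach a half-maximal effect in this assay.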